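Carbamate to Trifluoromethylcyclopropyl Amide on a Shared Core

A few compounds are considered here, and "the series" means these few. Any claim that something is new, unique, unknown or untested is made for them only; others in the source may bear on it.

Compound 2 `C[C@@H](CF)OC(=O)N1CCC(O[C@H]2CC[C@H](Oc3cnc(S(C)(=O)=O)cn3)CC2)CC1` and compound 1 `CC(C)(C)OC(=O)N1CCC(O[C@H]2CC[C@H](Oc3cnc(S(C)(=O)=O)cn3)CC2)CC1` share one core. In a functional assay on isolated protein for agonist activity at Glucose-dependent insulinotropic receptor (Homo sapiens), read by HTRF and cAMP accumulation (on this read-out higher numbers stand for larger maximal responses and lower numbers for smaller maximal responses), compound 1 gives 110%, and compound 2 gives 105%, the two lying within the scatter of each other; the step was a number 5 percentage points lower from compound 1 to compound 2 (within the scatter). Compound 3 `CS(=O)(=O)c1cnc(O[C@H]2CC[C@H](OC3CCN(C(=O)C4(C(F)(F)F)CC4)CC3)CC2)cn1` differs from compound 2 by a group of 7 heavy atoms (4 carbon, 3 fluorine; one three-membered non-aromatic ring of carbon only) in place of a group of 5 heavy atoms (3 carbon, 1 oxygen, 1 fluorine; no ring), on a carbonyl carbon. Going by the values given here, no measured step covers this change at the carbonyl carbon; the only step known altered the group on the oxygen and stayed within the scatter, so a step of a number 5 percentage points lower from compound 2 to compound 3 (within the scatter) is expected. Compound 3 is therefore estimated at 100%, between 80% and 118%.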

Compound 3, largest response reached (Emax), in percent of the reference or control that the assay uses: 107%
Beside the measured number, compound 3's estimate is 7 percentage points below it, and the stated range covers the measured number.
By their numbers in this assay, from the lowest: compounds 2, 3 and 1 (each within the scatter of the next).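

Going by these compounds alone, with the earlier compounds only the group on the oxygen had changed, whereas here the change falls on the carbonyl carbon itself, and the maximal response holds in this assay: the step is a number 2 percentage points higher from compound 2 to compound 3 (within the scatter) and, against tert-butoxy, a number 3 percentage points lower from compound 1 to compound 3 (within the scatter). So among these compounds, a 1-(trifluoromethyl)cyclopropyl on the carbonyl carbon serves as well as either oxygen-linked group. No supporting data explain this result. Still open, on these data alone, is whether a plain cyclopropyl without the trifluoromethyl, or an amine on the same carbonyl carbon, would keep this response.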